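The source may report more compounds than this note shows. Statements on the series, on what has been measured and on what is new or still open speak of the compounds shown alone.

Measured compounds:
compound 1 `O=C1C[C@H]2O[C@H]([C@H](O)c3ccccc3)[C@H](O)[C@H]2O1` gives 32500 nM in a functional assay on Jurkat cells (Homo sapiens) for antiproliferative activity, read by MTT assay, with a stated time of 72 h; a lower number here means a stronger inhibitor, a higher number a weaker inhibitor;
compound 2 `O=C1CC[C@@H]([C@@H](O)[C@H](O)[C@H](O)c2ccccc2)O1` gives 2230 nM;
compound 3 `O=C1C[C@H]2O[C@H]([C@H](OC(=O)c3ccccc3)c3ccccc3)[C@H](O)[C@H]2O1` gives 360 nM.

Compound 1 has the highest number of the three, so it is the weakest inhibitor here; compound 2 sits below it, and compound 3 is furthest away. Among the measured compounds shown here, the single one-place step that is known starts from compound 1: a 90-fold lower number from compound 1 to compound 3 (1.96 log units; beyond the scatter). Capping the hydroxy on the oxygen therefore gave a large gain.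

The unmeasured compound 4 `O=C1C[C@H]2O[C@H](Cc3ccccc3)[C@H](O)[C@H]2O1` differs from compound 1 in one place, (hydrogen in place of hydroxy on a saturated chain carbon bound to an aromatic carbon and a saturated ring carbon). For the measured compounds named here, no measured step removes this hydroxy outright, so the only guide is the step from compound 1 to compound 3, which shows that a change at this very oxygen can move the number a long way. Taking the hydroxy away is expected to lower the number too, but with less certainty and likely by a smaller margin than the benzoyl did, an estimated step of a 3.3-fold lower number from compound 1 to compound 4 (0.51 log units; beyond the scatter). Compound 4 is thus expected to give about 10000 nM, within a range from 2000 nM to 40000 nM.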

Compound 4, half-maximal inhibitory concentration: 2520 nM
For compound 4 the middle estimate is 4.0-fold (0.60 log units) above the measured one; measured number inside the range.
By their numbers in this assay, from the lowest: compound 3; then compounds 2 and 4 (each within the scatter of the next); then compound 1.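

Removing the hydroxy, with nothing added in its place, is itself a large change: the step is a 13-fold lower number from compound 1 to compound 4 (1.11 log units; beyond the scatter). So the lower number seen earlier with the benzoyl group does not depend on adding a large group at this place, and in this assay a free hydroxy on this saturated chain carbon is not needed for activity, since compounds 3 and 4 both lack it and both give lower numbers than compound 1. No measurement shown here explains why the hydroxy's loss has this effect.

The compounds shown leave open how much the benzoyl group contributes beyond removing the free hydroxy, which a small acetyl ester or a methyl ether at the same oxygen could help to separate. They also leave open how an amine or a fluorine in place of the hydroxy would behave on this carbon.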